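The compounds below may be only part of what the source reports. "The series", "measured", "known", "first", "only" and "open" are said of these compounds alone.

Three analogues of one shared core have been measured in a functional assay on HeLa cells (Homo sapiens) for inhibition, read by MTT assay, with a stated time of 72 h; on this read-out higher numbers stand for weaker inhibition and lower numbers for stronger inhibition. Compound 1 `CN(C(=O)NC(=O)c1cccc(C(F)(F)F)c1)c1nc(C(F)(F)F)c(C(=O)N/N=C/c2ccccc2C(F)(F)F)s1` gives 7.37 ug/mL. Compound 2 `CN(C(=O)NC(=O)c1ccc(F)c(F)c1)c1nc(C(F)(F)F)c(C(=O)N/N=C/c2ccccc2C(F)(F)F)s1` gives 9.24 ug/mL; the change shows a 1.3-fold higher number from compound 1 to compound 2 (0.10 log units; within the scatter). Compound 3 `CN(C(=O)NC(=O)c1c(Cl)cccc1Cl)c1nc(C(F)(F)F)c(C(=O)N/N=C/c2ccccc2C(F)(F)F)s1` gives 5.23 ug/mL, the lowest of the three numbers, yet it sits within the usual scatter of both neighbours: a 1.4-fold lower number from compound 1 to compound 3 (0.15 log units; within the scatter) and a 1.8-fold lower number from compound 2 to compound 3 (0.25 log units; within the scatter). So far, exchanging the aryl group on this carbonyl carbon has not moved the read-out beyond the scatter in any direction.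

Compound 4 `CN(C(=O)NC(=O)c1ccccc1F)c1nc(C(F)(F)F)c(C(=O)N/N=C/c2ccccc2C(F)(F)F)s1` is not yet measured. Its difference from compound 3 is 2-fluorophenyl in place of 2,6-dichlorophenyl on a carbonyl carbon. Among the measured compounds shown here, the steps that bear on this change are the two aryl swaps already seen at the same carbonyl carbon, a 1.4-fold lower number from compound 1 to compound 3 (0.15 log units; within the scatter) and a 1.8-fold lower number from compound 2 to compound 3 (0.25 log units; within the scatter), both within the scatter, as was a 1.3-fold higher number from compound 1 to compound 2 (0.10 log units; within the scatter). On that basis no step beyond the scatter is expected in this assay for compound 4 in either direction; the expected step reads a 1.3-fold higher number from compound 3 to compound 4 (0.11 log units; within the scatter). The estimate for compound 4 is 6.8 ug/mL, with a range from 3.2 ug/mL to 14.5 ug/mL, the range kept wide given that only three aryl variants anchor it.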

Compound 4, half-maximal inhibitory concentration: 10.1 ug/mL
For compound 4 the middle estimate is 1.5-fold (0.17 log units) below the measured one, and the stated range covers the measured number.
By their numbers in this assay, from the lowest: compounds 3, 1, 2 and 4 (each within the scatter of the next).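

In this assay, the exchange of 2,6-dichlorophenyl for 2-fluorophenyl on the carbonyl carbon, which takes the ring from two chlorine atoms to one fluorine atom, gives a 1.9-fold higher number from compound 3 to compound 4 (0.29 log units; within the scatter), and the comparisons with the other two aryl groups give a 1.1-fold higher number from compound 2 to compound 4 (0.04 log units; within the scatter) and a 1.4-fold higher number from compound 1 to compound 4 (0.14 log units; within the scatter). Among the compounds shown here, a fourth aryl group therefore extends the earlier picture: every step among compounds 1, 2, 3 and 4 lies within the scatter, so the read-out does not separate these four aryl groups, and no compound goes against this within the set. No available evidence bears on why these aryl groups read alike.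

As far as these compounds go, all four groups are phenyl rings carrying fluorine, chlorine or trifluoromethyl, so it stays open whether a phenyl ring bearing an amine or a carboxylic acid, or a longer alkyl chain in place of the ring, would give a step beyond the scatter at this carbonyl carbon. From the compounds shown here alone, it also stays open how the read-out responds to changes elsewhere on the shared core, which is the same in all four compounds.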